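A few compounds are considered here, and "the series" means these few. Any claim that something is new, unique, unknown or untested is made for them only; others in the source may bear on it.

In an ADME assay on Vero cells (Chlorocebus sabaeus) for cytotoxicity, read by fluorescence, with a stated time of 4 days (a higher number here means a weaker inhibitor, a lower number a stronger inhibitor), compound 2 `COC1=C(CC(C)(C)CNC(=O)c2ccccc2OC)C(=O)c2ccccc2C1=O` gives 27300 nM, and compound 1 `CC(C)(CNC(=O)c1ccc2ccccc2c1)CC1=C(O)C(=O)c2ccccc2C1=O` gives 46700 nM; the two numbers fall within the scatter of each other, so neither can be placed above the other. Compound 3 `COC1=C(CC(C)(C)CNC(=O)c2ccc3ccccc3c2)C(=O)c2ccccc2C1=O` has not yet been measured in this assay. It differs from compound 2 by naphthalen-2-yl in place of 2-methoxyphenyl on a carbonyl carbon. Among the compounds with values here, no measured pair here shows this change by itself, so the size of its effect is unknown. Compound 3 is expected to land close to compound 2, with a step of a 1.2-fold higher number from compound 2 to compound 3 (0.07 log units; within the scatter) that stays within the scatter, giving an estimated 32000 nM with a range from 11000 nM to 90000 nM.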

Compound 3, half-maximal inhibitory concentration: 36000 nM
Estimate against measurement, compound 3: 1.1-fold (0.05 log units) below; low and high end bracket the measured number.
By their numbers in this assay, from the lowest: compounds 2, 3 and 1 (each within the scatter of the next).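

In this assay, naphthalen-2-yl in place of 2-methoxyphenyl on a carbonyl carbon gives a 1.3-fold higher number from compound 2 to compound 3 (0.12 log units; within the scatter) and so has no readable effect, even though one more aromatic ring enters and a hydrogen-bond acceptor leaves. Methyl in place of hydrogen on an oxygen on an unsaturated carbon gives a 1.3-fold lower number from compound 1 to compound 3 (0.11 log units; within the scatter) and is equally unreadable. Within the data shown here, these are the first single-change comparisons here, and both stay within the scatter. Going by these compounds, whether a group such as an amine or a carboxylic acid on that carbonyl carbon would shift the number stays open. No measurement here explains the flat result.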